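The compounds below may be only part of what the source reports. "The series", "measured", "known", "first", "only" and "open" are said of these compounds alone.

Of the compounds shown here, three sharing one core have been tested so far: compound 1 `CC[C@H](C)[C@H](NC(=O)CN(c1nc(Cl)nc2[nH]cnc12)C1CC1)C(=O)O`, compound 2 `O=C(CN(c1nc(Cl)nc2[nH]cnc12)C1CC1)N[C@@H](CO)C(=O)O` and compound 3 `NCCCC[C@H](NC(=O)CN(c1nc(Cl)nc2[nH]cnc12)C1CC1)C(=O)O`. In a functional assay on the whole organism (Tail, strain ICR) with Mus musculus as the target, in the tail flick test, with a stated time of 150 min, at a dose of 25 umol/kg by the oral route (on this read-out lower numbers stand for a weaker effect and higher numbers for a stronger effect at the one dose given), compound 1 gives 6.71%, compound 2 gives 18.8% and compound 3 gives 11.6%, the second highest of the three numbers, though its gaps to both of the others lie within the scatter. Compound 4 `NC(=O)CC[C@H](NC(=O)CN(c1nc(Cl)nc2[nH]cnc12)C1CC1)C(=O)O` differs from compound 3 in one place: carbamoyl in place of 2-aminoethyl on a saturated chain carbon, three bonds along the chain from an amide-type nitrogen and a carbonyl carbon. For the measured compounds named here, the steps that bear on this side chain are a number 4.9 percentage points higher from compound 1 to compound 3 (within the scatter) and a number 7.2 percentage points lower from compound 2 to compound 3 (within the scatter), both within the scatter, while a number 12.1 percentage points higher from compound 1 to compound 2 (beyond the scatter) was modest. Exchanging one side chain for another has so far moved this assay little, so a step of only a number 0.4 percentage points higher from compound 3 to compound 4 (within the scatter) is expected. Compound 4 is therefore estimated at 12%, between 4% and 22%.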

Compound 4, a percentage reported as activity, at one dose (the size of the read-out at that dose, not a potency): 11.4%
The estimate for compound 4 lay 0.6 percentage points above the measured number, within the range that was stated.
By their numbers in this assay, from the lowest: compounds 1, 4, 3 and 2 (each within the scatter of the next, the first and the last beyond it).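

In this assay, carbamoyl in place of 2-aminoethyl gives a number 0.2 percentage points lower from compound 3 to compound 4 (within the scatter), so at this position these two side chains cannot be told apart. The other two steps, a number 7.4 percentage points lower from compound 2 to compound 4 (within the scatter) and a number 4.7 percentage points higher from compound 1 to compound 4 (within the scatter), leave 2-carbamoylethyl distinct from neither hydroxymethyl nor sec-butyl, even though those two differ from each other beyond the scatter. Nothing available explains this result. Going by these compounds, it remains open whether a carboxylic acid in place of carbamoyl, or a longer chain carrying the carbamoyl, would shift this read-out beyond the scatter.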